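The source may report more compounds than this note shows. Statements on the series, on what has been measured and on what is new or still open speak of the compounds shown alone.

In a functional assay on LOX IMVI cells (Homo sapiens) for antiproliferative activity, read by sulforhodamine B assay, with a stated time of 48 h (on this read-out lower numbers stand for stronger inhibition and higher numbers for weaker inhibition), compound 3 `COc1ccc(C(=O)Nc2cccc(-c3ccnc4c(NC(C)=O)cccc34)c2)cc1OC` gives 800 nM, which places it second highest among the three numbers shown. Compound 2 `Nc1cccc2c(-c3cccc(NC(=O)c4ccc5c(c4)OCCO5)c3)ccnc12` gives 460 nM, close enough to compound 3 that the two cannot be separated with confidence. Compound 1 `Nc1cccc2c(-c3cccc(NC(=O)c4ccc(Cl)c(C(F)(F)F)c4)c3)ccnc12` gives 3200 nM, clearly weaker than compound 2, and these two share the same core and differ only in the aromatic group on the amide carbonyl. Compound 4 `CC(=O)Nc1cccc2c(-c3cccc(NC(=O)c4ccc(Cl)c(C(F)(F)F)c4)c3)ccnc12` keeps the acetamido core of compound 3 but carries 4-chloro-3-(trifluoromethyl)phenyl in place of 3,4-dimethoxyphenyl on a carbonyl carbon. Since compound 1, with this same carbonyl group, gives 3200 nM while compound 2 gives 460 nM, a step toward weaker inhibition beyond the scatter is expected: a 4.4-fold higher number from compound 3 to compound 4 (0.64 log units; beyond the scatter). Compound 4 is therefore estimated at 3500 nM, with a likely range from 1200 nM to 10000 nM.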

Compound 4, half-maximal inhibitory concentration: 3400 nM
Compound 4: middle estimate off by 1.0-fold (0.01 log units), on the high side; low and high end bracket the measured number.
By their numbers in this assay, from the lowest: compounds 2 and 3 (each within the scatter of the next); then compounds 1 and 4 (each within the scatter of the next).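

In this assay, for the compounds shown here, 4-chloro-3-(trifluoromethyl)phenyl in place of 3,4-dimethoxyphenyl on a carbonyl carbon gives a 4.3-fold higher number from compound 3 to compound 4 (0.63 log units; beyond the scatter) as a single change, the first such reading for this position. Acetyl in place of hydrogen on a nitrogen on an aromatic ring gives a 1.1-fold higher number from compound 1 to compound 4 (0.03 log units; within the scatter) and so, with 4-chloro-3-(trifluoromethyl)phenyl in place, shows no change that can be told from the scatter. Nothing measured here gives a reason for either step.

From the compounds shown here alone, what a longer chain such as butanoyl would give in place of acetyl on that nitrogen stays open. So does whether acetyl behaves the same way with 3,4-dimethoxyphenyl on the carbonyl carbon.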